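The compounds below may be only part of what the source reports. "The series", "measured", "known", "first", "only" and "open" are said of these compounds alone.

Measured so far in a functional assay on OVCAR-5 cells (Homo sapiens) for inhibition, read by sulforhodamine B assay, with a stated time of 48 h; a higher number here means a weaker inhibitor of growth, a lower number a stronger inhibitor of growth:
Compound 1 `O=C(Cc1csc2nc(-c3ccc(Br)cc3)cn12)N/N=C/c1ccccc1`: > 100000 nM, a limit of the assay
Compound 2 `O=C(Cc1csc2nc(-c3ccc(Br)cc3)cn12)N/N=C/c1ccccc1O`: 31600 nM

For the measured compounds named here, compound 2 holds the only value that is not a limit. Compound 3 `O=C(Cc1csc2nc(-c3ccc(Br)cc3)cn12)N/N=C/c1ccc(O)cc1` differs from it as follows: 4-hydroxyphenyl in place of 2-hydroxyphenyl on a carbon with a double bond to nitrogen. In words, it carries 4-hydroxyphenyl in place of 2-hydroxyphenyl on a carbon with a double bond to nitrogen. Going by the values given here, the one measured step that bears on this is an at least 3.1-fold lower number from compound 1 to compound 2 (0.50 log units; beyond the scatter), which adds the hydroxy group but does not test where it sits. A change of about that size or less is therefore expected in this assay, leaning towards a higher number. The expected step is a 1.3-fold higher number from compound 2 to compound 3 (0.10 log units; within the scatter), which would remain within the scatter. For compound 3 the estimate is 40000 nM, with an expected range of 14000 nM to 100000 nM.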

Compound 3, concentration for total growth inhibition: > 100000 nM
Compound 3: only a limit was reported (the forecaster's own chance of this, stated with the estimate: 35%); middle value at least 2.5-fold (0.39 log units) away from the limit.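

For the compounds shown here, the earlier step showed only that adding a hydroxy group can lower the number; in this assay, the position of that group also proves to matter, with 4-hydroxyphenyl in place of 2-hydroxyphenyl giving an at least 3.1-fold higher number from compound 2 to compound 3 (0.50 log units; beyond the scatter). Of the three compounds, only compound 2, with 2-hydroxyphenyl, has a value that is not a limit. The step linking the other two compounds cannot be read, as both of their values are limits: the limit of > 100000 nM in this assay, at which 2 of the 3 values shown sit.

On these data alone, it remains open whether an amine or a carboxylic acid in place of the hydroxy group would lower the number as 2-hydroxyphenyl does.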